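Fluorine on the Phenyl Ring Across Two Cores

A few compounds are considered here, and "the series" means these few. Any claim that something is new, unique, unknown or untested is made for them only; others in the source may bear on it.

Compound 1 `Cc1c(O)ccc2c1[C@H](Cn1cc(-c3ccccc3)nn1)[C@@]13CC(=O)[C@@](C)(CC[C@@H]21)C3`: in a functional assay on MCF7 cells (Homo sapiens) for cytotoxicity, read by MTT assay, with a stated time of 4 days (on this read-out higher numbers stand for weaker inhibition and lower numbers for stronger inhibition), compound 1 gives > 20000 nM, which is a limit of the assay and not a number.
Compound 2 `Cc1c(O)ccc2c1[C@H](Cn1cc(-c3ccc(F)cc3)nn1)[C@@]13CC(=O)[C@@](C)(CC[C@@H]21)C3`: in this assay compound 2 gives > 20000 nM, again only a limit.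
Compound 3 `C=C1C[C@]23C[C@@]1(O)CC[C@H]2c1cc(Br)c(O)c(C)c1[C@@H]3Cn1cc(-c2ccccc2)nn1`: in this assay compound 3 gives > 20000 nM, again only a limit.

The change from compound 1 to compound 2 is fluoro in place of hydrogen on an aromatic carbon. Going by these compounds, both values being limits, the step that the two limits leave unreadable from compound 1 to compound 2 cannot be read, so what the fluoro does on this core stays unknown. All three results sit at one point: the limit of > 20000 nM in this assay, at which 3 of the 3 values shown sit. Compound 3 carries a different core; the difference between the two cores is not broken down here. Compound 4 `C=C1C[C@]23C[C@@]1(O)CC[C@H]2c1cc(Br)c(O)c(C)c1[C@@H]3Cn1cc(-c2ccc(F)cc2)nn1` is the not yet measured partner of compound 3, and the change from compound 3 to compound 4 is fluoro in place of hydrogen on an aromatic carbon, the same change as that between compound 1 and compound 2, made at a place described in the same words. Because compound 3 shows > 20000 nM, a limit only, compound 4 is expected to stay at the limit too, an expected step that the limit leaves unreadable from compound 3 to compound 4. Compound 4 is therefore estimated at 30000 nM.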

Compound 4, half-maximal inhibitory concentration: 19200 nM
For compound 4 the middle estimate is 1.6-fold (0.19 log units) above the measured one, within the range that was stated.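

In this assay compound 3 gives > 20000 nM as its result, which is a limit of the assay and not a number. Moving from phenyl to 4-fluorophenyl on this core gives an at least 1.0-fold lower number from compound 3 to compound 4 (0.01 log units; that floor lies within the scatter) as the only reading, so the pair shows a floor and not the true size of the change, and no real effect of the fluoro can be claimed from it. The same change on the core of compound 1 cannot be read, with both of its values being limits, so there is no size to carry from one core to the other, and the data neither support nor rule out a shared effect, with most results sitting at one point: the limit of > 20000 nM in this assay, at which 3 of the 4 values shown sit.

The compounds shown leave open what an amine or a carboxylic acid would do in place of the fluoro on either core. They also leave open how far any change on these cores can move the result well away from the limit.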